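This account rests on a few compounds, and the source may have more. Where it says the series, first, only, none or still open, it means among the compounds named here.

Measured in an ADME assay on BJ cells (Homo sapiens), read by MTT assay, with a stated time of 72 h; a higher number here means a weaker inhibitor, a lower number a stronger inhibitor:
- compound 1 `O=c1[nH]cnc2c1c(-c1cc3ccccc3o1)cn2[C@@H]1O[C@H](CO)[C@@H](O)[C@H]1O`: 62700 nM
- compound 2 `Nc1nc2c(c(-c3ccoc3)cn2[C@@H]2O[C@H](CO)[C@@H](O)[C@H]2O)c(=O)[nH]1`: 21500 nM
- compound 3 `Nc1nc2c(c(-c3ccsc3)cn2[C@@H]2O[C@H](CO)[C@@H](O)[C@H]2O)c(=O)[nH]1`: > 100000 nM

The entry for compound 3 is a limit of the assay and not a number. Compound 3 thus stands at the limit of > 100000 nM in this assay, at which 1 of the 3 values shown sits, so its true value is not known.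

The next compound, compound 4 `Nc1nc2c(c(-c3cc4ccccc4o3)cn2[C@@H]2O[C@H](CO)[C@@H](O)[C@H]2O)c(=O)[nH]1`, has 1-benzofuran-2-yl in place of thiophen-3-yl on an aromatic carbon.

Within the data shown here, only one measured step changes a group at this place. It is an at least 4.6-fold higher number from compound 2 to compound 3 (0.66 log units; beyond the scatter), with thiophen-3-yl in place of furan-3-yl, and it lies beyond the scatter. So the group at this place can move the number in this assay, though no measured step shows what a 1-benzofuran-2-yl group does on this core. The nearest guide is compound 1, which carries that same group on a core that is not quite the same and gives 62700 nM.

On that guide, a step towards a lower number is expected, though compound 4 could still reach the limit. The estimated value for compound 4 is 45000 nM, with an expected range from 12000 nM to 100000 nM. This estimate means an expected at least 2.2-fold lower number from compound 3 to compound 4 (0.34 log units; beyond the scatter).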

Compound 4, half-maximal inhibitory concentration: > 100000 nM
Compound 4 gave a limit, no number; the forecaster's own chance of this, stated with the estimate: 25%; middle value at least 2.2-fold (0.34 log units) away from the limit.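

On the shared core, 1-benzofuran-2-yl in place of furan-3-yl gives an at least 4.6-fold higher number from compound 2 to compound 4 (0.66 log units; beyond the scatter) in this assay, so a second group at this place, with a fused six-membered aromatic ring added, also moves the number up from that of compound 2. With 1-benzofuran-2-yl kept in place, amino in place of hydrogen on the core gives an at least 1.5-fold higher number from compound 1 to compound 4 (0.20 log units; that floor lies within the scatter), but that floor lies within the scatter, so this pair does not show that the amino group itself changes the number. The entries for compound 3 and compound 4 are both limits of the assay and not numbers, so the step between them cannot be read: the limit of > 100000 nM in this assay, at which 2 of the 4 values shown sit.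

As far as these compounds go, it remains open how far compound 3 and compound 4 really lie from each other, and so whether thiophen-3-yl and 1-benzofuran-2-yl differ at all in this assay. From the compounds shown here alone, it is also open what a group of another kind at this place, such as an amine or a short alkyl chain, would do to the number set by compound 2.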